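Dropping One Methoxy Group: an Expectation for Compound 3

A few compounds are considered here, and "the series" means these few. Any claim that something is new, unique, unknown or untested is made for them only; others in the source may bear on it.

Measured so far:
Compound 2, `COc1ccc(Nc2cccc3c(C)c(C)sc23)cc1OC`: 100%
Compound 1, `Cc1sc2c(Nc3ccc(C#N)cc3)cccc2c1C`: 71%

Of the compounds shown here, two have been tested in a functional assay for inhibition, with a stated time of 2 h, tested at 0.125 g/L; on this read-out higher numbers stand for more inhibition at the one concentration tested (going by the name of the read-out) and lower numbers for less inhibition. Compound 2 stands highest of the two numbers; its nearest neighbour is compound 1, whose reading in this assay of 71% lies well below, beyond the usual scatter of repeated measurements.

Compound 3 `COc1ccc(Nc2cccc3c(C)c(C)sc23)cc1` differs from compound 2 in one place only: hydrogen in place of methoxy on an aromatic carbon. One methoxy group is lost while the other methoxy group remains.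

Among the compounds with values here, no measured pair shows this particular change, so the size of the step is uncertain. A small drop, or none beyond the scatter, is expected, because compound 2 gives 100% and little room lies above it. Compound 3 is expected to sit slightly lower, the expected step being a number 10 percentage points lower from compound 2 to compound 3 (within the scatter). Compound 3 is therefore estimated at 90%, with a range from 70% to 100%.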

Compound 3, a percentage reported as inhibition, at one concentration (the size of the read-out at that concentration, not a potency): 100%
Compound 3: the middle estimate sits 10 percentage points below what was measured; measured number inside the range.
By their numbers in this assay, from the lowest: compound 1; then compounds 2 and 3 (each within the scatter of the next).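

In this assay removing one methoxy group gives no change at the digits printed from compound 2 to compound 3 (within the scatter), so at the one concentration tested, that methoxy group is not needed for the full reading, although compound 2 and compound 3 both sit at the top of the scale, where any difference in potency could stay hidden. Exchanging the cyano group for methoxy gives a number 29 percentage points higher from compound 1 to compound 3 (beyond the scatter), which shows that the reading does respond to the group on this ring, even though losing the second methoxy group left it unmoved. No supporting measurement is available to explain either step.

From the compounds shown here alone, it remains open whether an amine or a carboxylic acid on this ring would hold the reading, and whether the remaining methoxy group can itself be replaced by hydrogen. Telling compound 2 and compound 3 apart would take a test at lower concentrations.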